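Swapping cyano for chloro on a shared core

The source may report more compounds than this note shows. Statements on the series, on what has been measured and on what is new or still open speak of the compounds shown alone.

- compound 1 `N#Cc1ccc(S(=O)(=O)Nc2cccc3c(C#N)c[nH]c23)cc1`: 0.12 ug/mL
- compound 2 `N#Cc1c[nH]c2c(NS(=O)(=O)c3ccc(N)cc3)cccc12`: 0.28 ug/mL
- compound 3 `CS(=O)(=O)Nc1ccc(S(=O)(=O)Nc2cccc3c(C#N)c[nH]c23)cc1`: 1.2 ug/mL

In a functional assay on MC-38 cells (Mus musculus) for antiproliferative activity (a lower number here means a stronger inhibitor, a higher number a weaker inhibitor), compound 2 lies between the other two measured compounds. Its two neighbouring steps are a 2.3-fold higher number from compound 1 to compound 2 (0.37 log units; beyond the scatter) and a 4.3-fold higher number from compound 2 to compound 3 (0.63 log units; beyond the scatter).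

Compound 4 `Nc1ccc(S(=O)(=O)Nc2cccc3c(Cl)c[nH]c23)cc1` keeps the rest of compound 2 but carries chloro in place of cyano on an aromatic carbon of the five-membered aromatic ring: chloro in place of cyano on an aromatic carbon.

Within the data shown here, no measured step changes this position. All three steps alter a different group, which is cyano in compound 1, amino in compound 2 and methanesulfonamido in compound 3. They therefore offer only a rough sense of scale, from a 2.3-fold higher number from compound 1 to compound 2 (0.37 log units; beyond the scatter) up to a 10-fold higher number from compound 1 to compound 3 (1.00 log units; beyond the scatter). They give no direction for the new change, so a small step in this assay is expected, possibly none beyond the scatter, with a wide margin either way.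

The expected step is a 1.1-fold lower number from compound 2 to compound 4 (0.05 log units; within the scatter).

For compound 4, the estimated value is 0.25 ug/mL, with an expected range of 0.07 ug/mL to 0.9 ug/mL.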

Compound 4, half-maximal inhibitory concentration: 0.23 ug/mL
Estimate against measurement, compound 4: 1.1-fold (0.04 log units) above; measured number inside the range.
By their numbers in this assay, from the lowest: compounds 1, 4 and 2 (each within the scatter of the next, the first and the last beyond it); then compound 3.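

In this assay, among these compounds, the first measured change at this position gives a 1.2-fold lower number from compound 2 to compound 4 (0.09 log units; within the scatter) and so compound 2 and compound 4 cannot be told apart. With the amino group held constant, chloro can therefore stand in for cyano on this aromatic carbon of the five-membered ring with no difference that this assay can resolve. Nothing available here explains why the two groups give such similar results.

Chloro appears here only alongside amino, so it remains open whether the match between chloro and cyano would hold with the cyano or methanesulfonamido group that compound 1 and compound 3 carry in its place. Also open, going by these compounds, is how a different group at this position, such as bromo, methyl or a carboxylic acid, would compare.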